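Chloro in place of hydroxy: compound 1 to compound 3

This account rests on a few compounds, and the source may have more. Where it says the series, first, only, none or still open, it means among the compounds named here.

Among the measured compounds shown here, compound 1, `CC(/C=N/Nc1ccc([N+](=O)[O-])cc1)=N\NC(=O)c1ccc(O)cc1`, is the only compound here that gives a number in an ADME assay on J774 cells (Mus musculus, strain BALB/c) for cytotoxicity, read by resazurin assay, with a stated time of 72 h (on this read-out higher numbers stand for lower toxicity in this test and lower numbers for higher toxicity in this test), where compound 1 comes out at 51000 nM. For the measured compounds named here, its one measured neighbour, compound 2, `COc1cc(C(=O)N/N=C(C)/C=N/Nc2ccc([N+](=O)[O-])cc2)ccc1O`, carries a methoxy in place of hydrogen on an aromatic carbon. In this assay compound 2 reaches only a limit, > 100000 nM. The step that follows is an at least 1.9-fold higher number from compound 1 to compound 2 (0.29 log units; that floor lies within the scatter), and its floor sits at the limit of > 100000 nM in this assay, at which 1 of the 2 values shown sits.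

Compound 3, `CC(/C=N/Nc1ccc([N+](=O)[O-])cc1)=N\NC(=O)c1ccc(Cl)cc1`, differs from compound 1 as follows: chloro in place of hydroxy on an aromatic carbon. Going by the values given here, no measured step here exchanges a hydroxy for a chloro, so the step from compound 1 to compound 2 bears on it only by showing that a change on the same ring, 4-hydroxyphenyl carried over into a ring with an added methoxy, left the number at most within the scatter. The account therefore expects for compound 3 no step beyond the scatter in this assay, a 1.1-fold lower number from compound 1 to compound 3 (0.05 log units; within the scatter), with the estimate for compound 3 set at 45000 nM, between 15000 nM and 100000 nM.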

Compound 3, half-maximal cytotoxic concentration: 63900 nM
Compound 3: middle estimate off by 1.4-fold (0.15 log units), on the low side, within the range that was stated.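

In this assay, the swap on an aromatic carbon para to a large group reads a 1.3-fold higher number from compound 1 to compound 3 (0.10 log units; within the scatter), so hydroxy and chloro cannot be told apart at this position on this read-out. The earlier step added a methoxy and left the hydroxy in place, whereas this one removes the hydroxy itself, along with its hydrogen-bond donor and acceptor, and the number still stays within the scatter of that of compound 1. The comparison that takes in the methoxy as well reads an at least 1.5-fold lower number from compound 2 to compound 3 (0.19 log units; that floor lies within the scatter), and it is only a floor, since compound 2 gives a limit and not a number: the limit of > 100000 nM in this assay, at which 1 of the 3 values shown sits.

No step among these three compounds is shown to lie beyond the scatter, so the compounds give no sign yet of any change at this ring that moves the number in a way that can be read. From the compounds shown here alone, whether an amine or a carboxylic acid at this same position would do so stays open, as does whether a chloro together with a methoxy on the ring would read like compound 3.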